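Shortening the Amide Nitrogen Substituent in a Hydroxamate Series

This account rests on a few compounds, and the source may have more. Where it says the series, first, only, none or still open, it means among the compounds named here.

Compound 1 `CCN(C(=O)c1cc(C(C)C)c(O)cc1O)c1ccc(NC(=O)CCCCCCC(=O)NO)cc1` gives 1380 nM in a functional assay on NCI-H1975 cells (Homo sapiens) for inhibition, read by sulforhodamine B assay, with a stated time of 48 h; on this read-out higher numbers stand for weaker inhibition of growth and lower numbers for stronger inhibition of growth. Compound 3 `CCN(C(=O)c1cc(C(C)C)c(O)cc1O)c1cccc(NC(=O)CCCCCCC(=O)NO)c1` gives 940 nM. Compound 2 `CC(C)c1cc(C(=O)N(c2ccc(NC(=O)CCCCCCC(=O)NO)cc2)C(C)C)c(O)cc1O` reaches only the limit of this assay, > 10000 nM.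

Among the measured compounds shown here, the one counted step among the measured compounds runs from compound 2 to compound 1: hydrogen in place of methyl on a saturated chain carbon bound to an amide-type nitrogen and a saturated chain carbon. It gives an at least 7.2-fold lower number from compound 2 to compound 1 (0.86 log units; beyond the scatter), a size that rests on the limit of > 10000 nM in this assay, at which 1 of the 3 values shown sits, rather than on a full number. The difference between the cores of compound 2 and compound 3 is not broken down here; the values of compound 1 and compound 3 lie within the scatter of each other.

Compound 4 `CC(C)c1cc(C(=O)N(C)c2cccc(NC(=O)CCCCCCC(=O)NO)c2)c(O)cc1O` has not been measured. It differs from compound 3 by hydrogen in place of methyl on a saturated chain carbon bound to an amide-type nitrogen, the same kind of change as the measured step, though there the leaving methyl sat on a carbon also bound to a saturated chain carbon. Given that compound 1 improved on compound 2 by an at least 7.2-fold lower number from compound 2 to compound 1 (0.86 log units; beyond the scatter), a modest step is expected here too, with compound 4 estimated at a 1.3-fold lower number from compound 3 to compound 4 (0.13 log units; within the scatter). Compound 4 is expected to give 700 nM, between 300 nM and 1600 nM.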

Compound 4, concentration for 50% growth inhibition: 1660 nM
Compound 4: middle estimate off by 2.4-fold (0.38 log units), on the low side; the measured number lies above the stated range.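

In this assay the change from ethyl to methyl on the amide-type nitrogen gives a 1.8-fold higher number from compound 3 to compound 4 (0.25 log units; within the scatter), so on this core it brings no shift beyond the scatter. Set beside the earlier step, the same kind of change does not carry over in size from one core to the other: the same change on two cores in this assay, an at least 7.2-fold lower number (0.86 log units; beyond the scatter) from compound 2 to compound 1 and a 1.8-fold higher number (0.25 log units; within the scatter) from compound 3 to compound 4, at least 12-fold (1.10 log units) apart, beyond the scatter of two such steps. This does not fix the true size of that gap, for the value of compound 2 is a limit and not a number: the limit of > 10000 nM in this assay, at which 1 of the 4 values shown sits.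

The compounds shown leave open whether the gap follows the core or the carbon that loses its methyl, as the two steps differ in both. They also leave open how a propyl group or a bare hydrogen on the amide-type nitrogen would behave on either core.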